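The source may hold more compounds than are shown below. What is called first, only, known or untested is meant among the compounds shown, and "the series" means these compounds.

Compounds measured in a toxicity assay on Vero cells (Chlorocebus sabaeus) for cytotoxicity; a higher number here means that more compound is tolerated, a lower number that less compound is tolerated:
Compound 1, `COc1nc(C(C)(C)C)ccc1[C@@H](c1ccccc1)[C@@](O)(CCN(C)C)c1cccc2ccccc12`, gives 27.6 ug/mL.
Compound 2, `COc1ccc(-c2ccc([C@@H](c3ccccc3)[C@@](O)(CCN(C)C)c3cccc4ccccc34)c(OC)n2)cc1`, gives > 50 ug/mL.

For compound 2 the value > 50 ug/mL is a limit of this assay and not a number, so its place on the scale is known only as a floor (the limit of > 50 ug/mL in this assay, at which 1 of the 2 values shown sits). Within the data shown here, the only step measured, an at least 1.8-fold higher number from compound 1 to compound 2 (0.25 log units; that floor lies within the scatter), comes from putting 4-methoxyphenyl in place of tert-butyl on an aromatic carbon.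

Compound 3, `COc1nc(-c2ccc(Cl)c(F)c2)ccc1[C@@H](c1ccccc1)[C@@](O)(CCN(C)C)c1cccc2ccccc12`, differs from compound 2 by 4-chloro-3-fluorophenyl in place of 4-methoxyphenyl on an aromatic carbon. Among the measured compounds shown here, no measured step exchanges one aryl group for another; the step from compound 1 to compound 2 concerns a different change and sets only a floor for compound 2. Compound 3 is therefore expected to sit close to compound 2 in this assay, with an expected step of an at least 1.1-fold lower number from compound 2 to compound 3 (0.04 log units; that floor lies within the scatter), no clear direction beyond the scatter. Compound 3 is estimated at 45 ug/mL, within 22 ug/mL to 90 ug/mL, and it may again be reported only as a limit.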

Compound 3, half-maximal cytotoxic concentration: > 50 ug/mL
Compound 3: no number, only a limit (the forecaster's own chance of this, stated with the estimate: 45%); middle value at least 1.1-fold (0.04 log units) away from the limit.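

In this assay compound 3 gives > 50 ug/mL, which is again a limit of the assay and not a number. The exchange of 4-methoxyphenyl for 4-chloro-3-fluorophenyl, on the aromatic carbon next to the ring nitrogen, cannot be read, because compound 2 and compound 3 both rest on the same limit: the limit of > 50 ug/mL in this assay, at which 2 of the 3 values shown sit. What this adds is that a second aryl group, with a chlorine and a fluorine in place of the methoxy group, also gives a floor when it replaces tert-butyl, an at least 1.8-fold higher number from compound 1 to compound 3 (0.25 log units; that floor lies within the scatter), so the two aryl groups at this position are alike only in that neither gives a value under the limit.

Going by these compounds, how far compound 2 and compound 3 lie beyond the limit stays open, and with it whether the two aryl groups differ at all in this assay and whether either truly parts from tert-butyl. Also open, on these data alone, is where a group of another kind at this place would fall, such as an amine, a carboxylic acid or a plain methyl.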